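The source may hold more compounds than are shown below. What is called first, only, known or untested is meant among the compounds shown, and "the series" means these compounds.

Compound 1 `CCO[C@H]1CC[C@H]2CCN(C)[C@H]2C1` is the starting point, and in an assay on HEK293 cells for antagonist activity at Nicotinic acetylcholine receptor alpha-4/beta-2 (Mus musculus), read by FLIPR, using a membrane potential dye (a lower number here means a stronger inhibitor, a higher number a weaker inhibitor), compound 1 gives > 300000 nM, a limit of the assay rather than a number. Compound 2 `CN1CC[C@@H]2CC[C@H](OCc3ccccc3)C[C@@H]21` likewise gives > 300000 nM, again a limit. Compound 3 `CCO[C@H]1CC=C2CCN(C)[C@H]2C1` also gives > 300000 nM, once more a limit. Within the data shown here, the one measured step between neighbours, a step that the two limits leave unreadable from compound 1 to compound 2, therefore carries no readable size, since both ends sit at the same limit; the evidence consists only of the limit of > 300000 nM in this assay, at which 3 of the 3 values shown sit. Compound 4 `CN1CC[C@@H]2CC[C@H](O)C[C@@H]21` differs from compound 1 by hydrogen in place of ethyl on an oxygen on a saturated carbon. Among the measured compounds shown here, no measured step speaks directly to the change from an ethyl to a hydrogen on that oxygen, and nothing among the three measured compounds rises out of the limit in this assay, so no direction can be read for this assay beyond the scatter. The estimate for compound 4 is 500000 nM, within 100000 nM to 3000000 nM, most probably again reported only as a limit. The expected step from compound 1 to compound 4 is a step that the limit leaves unreadable from compound 1 to compound 4.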

Compound 4, half-maximal inhibitory concentration: > 300000 nM
Compound 4 ended at the assay's limit; the forecaster's own chance of this, stated with the estimate: 85%; the middle value is on the limit's open side.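

Compound 1 and compound 4 both sit at a limit of this assay, so the step between them cannot be read. The compounds shown leave open whether any group on that oxygen would give a readable value, as the evidence is still only this: the limit of > 300000 nM in this assay, at which 4 of the 4 values shown sit.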